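From Fluoro to Hydrogen: What Compound 3 May Show

The compounds below may be only part of what the source reports. "The series", "measured", "known", "first", "only" and "open" are said of these compounds alone.

Compound 1 `C=C1C[C@]23C[C@@]1(O)CC[C@H]2c1ccc(OS(=O)(=O)c2ccc(C)cc2)c(C)c1[C@@H]3Cn1cc(-c2ccc(Cl)cc2)nn1` and compound 2 `C=C1C[C@]23C[C@@]1(O)CC[C@H]2c1ccc(OS(=O)(=O)c2ccc(C)cc2)c(C)c1[C@@H]3Cn1cc(-c2ccc(F)cc2)nn1` share one core and differ only at a single aromatic carbon. In a functional assay on SMMC-7721 cells (Homo sapiens) for cytotoxicity, read by MTT assay, with a stated time of 4 days (a lower number here means a stronger inhibitor, a higher number a weaker inhibitor), compound 1 gives only a limit of the assay, > 20000 nM. In this assay compound 2 likewise gives only a limit, > 20000 nM. The step that the two limits leave unreadable from compound 1 to compound 2, fluoro in place of chloro on an aromatic carbon, cannot be sized because both values sit at the limit of > 20000 nM in this assay, at which 2 of the 2 values shown sit. Compound 3 `C=C1C[C@]23C[C@@]1(O)CC[C@H]2c1ccc(OS(=O)(=O)c2ccc(C)cc2)c(C)c1[C@@H]3Cn1cc(-c2ccccc2)nn1` is the next member: hydrogen in place of fluoro on an aromatic carbon. Within the data shown here, the one measured step bears on this change only in that both of its ends sit at the limit, so it offers no readable size or direction. For compound 3 the expected step is a step that the limit leaves unreadable from compound 2 to compound 3, that is, none beyond the scatter. Compound 3 is therefore estimated at 30000 nM, within 8000 nM to 100000 nM, and will most likely be reported again only as a limit.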

Compound 3, half-maximal inhibitory concentration: > 20000 nM
Compound 3: a limit, no number; the forecaster's own chance of this, stated with the estimate: 80%; the middle value does not contradict the limit.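

Among these compounds, no step can be sized among compound 1, compound 2 and compound 3, because all three give only a limit in this assay: the limit of > 20000 nM in this assay, at which 3 of the 3 values shown sit. The compounds shown leave open how chloro, fluoro and hydrogen at this one place compare in strength.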